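The compounds below may be only part of what the source reports. "The series", "measured", "known", "first", "only" and "open" are said of these compounds alone.

Of the compounds shown here, three of a shared core have been tested in an ADME assay on CEM-SS cells (Homo sapiens) for cytotoxicity, read by XTT assay, with a stated time of 6 days; a higher number here means that more compound is tolerated, a lower number that less compound is tolerated. Compound 1 `CCCC(=O)OCSc1ccccc1C(=O)NCC(N)=O` gives > 100 uM, which is a limit of the assay and not a number (the limit of > 100 uM in this assay, at which 1 of the 3 values shown sits). Compound 2 `CCCC(=O)OCSc1ccccc1C(=O)NCCCCC(N)=O` gives 51.7 uM, and compound 3 `CCCC(=O)OCSc1ccccc1C(=O)N[C@@H]1CCC[C@H]1C(N)=O` gives 43.7 uM. Among the two numbers, compound 2 stands highest, with compound 3 nearest a 1.2-fold lower number from compound 2 to compound 3 (0.07 log units; within the scatter). The steps from compound 1 are an at least 1.9-fold lower number from compound 1 to compound 2 (0.28 log units; that floor lies within the scatter) and an at least 2.2-fold lower number from compound 1 to compound 3 (0.35 log units; beyond the scatter). Compound 4 `C#CCNC(=O)CNC(=O)c1ccccc1SCOC(=O)CCC` differs from compound 2 by propargylcarbamoyl in place of 3-carbamoylpropyl on a saturated chain carbon bound to an amide-type nitrogen. Going by the values given here, no measured step changes the chain end in this way, and the steps among compounds 1, 2 and 3 are modest, so compound 4 is expected to sit near compound 2, giving a 1.0-fold lower number from compound 2 to compound 4 (0.01 log units; within the scatter). In this assay compound 4 is estimated at 50 uM, between 20 uM and 100 uM.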

Compound 4, half-maximal toxic concentration: 95.4 uM
Compound 4: the middle estimate sits 1.9-fold (0.28 log units) below what was measured; low and high end bracket the measured number.
By their numbers in this assay, from the lowest: compounds 3, 2 and 4 (each within the scatter of the next, the first and the last beyond it). At a limit, above all of these: compound 1.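

In this assay, propargylcarbamoyl in place of 3-carbamoylpropyl on a saturated chain carbon bound to an amide-type nitrogen gives a 1.8-fold higher number from compound 2 to compound 4 (0.27 log units; within the scatter), so this change stays within the scatter. Going by these compounds alone, replacing the 2-carbamoylcyclopentyl group with (propargylcarbamoyl)methyl gives a 2.2-fold higher number from compound 3 to compound 4 (0.34 log units; beyond the scatter), the first step in this set that goes clearly upward. Propargyl in place of hydrogen on an amide-type nitrogen gives an at least 1.0-fold lower number from compound 1 to compound 4 (0.02 log units; that floor lies within the scatter). Compound 1 gives > 100 uM, which is a limit of the assay and not a number. On these data alone, what a carboxylic acid or an amine would do at this chain end stays open. So does whether the triple bond matters, which a saturated propylcarbamoyl group would test.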